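A few compounds are considered here, and "the series" means these few. Any claim that something is new, unique, unknown or untested is made for them only; others in the source may bear on it.

Measured so far in a functional assay on SW-620 cells (Homo sapiens) for inhibition, read by sulforhodamine B assay, with a stated time of 48 h; on this read-out higher numbers stand for weaker inhibition of growth and lower numbers for stronger inhibition of growth:
- compound 1 `COc1cc(-c2nn(-c3cccc(NC(=O)Nc4ccc(Cl)c(Cl)c4)c3)cc2-c2ccncc2)ccc1Cl` gives 1590 nM
- compound 2 `COc1cc(-c2nn(-c3cccc(NC(=O)c4ccc(Cl)c(C(F)(F)F)c4)c3)cc2-c2ccncc2)ccc1Cl` gives 4750 nM

Of the two, compound 2 holds the higher number at 4750 nM and is the weaker inhibitor of growth, with the gap beyond the scatter. The next structure is compound 3 `COc1cc(-c2nn(-c3cccc(NC(=O)c4ccccc4)c3)cc2-c2ccncc2)ccc1Cl`, which carries phenyl in place of 4-chloro-3-(trifluoromethyl)phenyl on a carbonyl carbon.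

For the measured compounds named here, only one measured step bears on this change: a 3.0-fold higher number from compound 1 to compound 2 (0.48 log units; beyond the scatter). That modest step falls on the same carbonyl carbon, but it exchanges a different group. Going by the values given here, no measured compound carries plain phenyl there, so the evidence for the new step is thin. In this assay a step no larger than the measured one is expected, leaning towards a higher number and probably not clearing the scatter: a 1.4-fold higher number from compound 2 to compound 3 (0.14 log units; within the scatter). For compound 3 the estimated value is 6500 nM, with an expected range of 2200 nM to 19000 nM.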

Compound 3, concentration for 50% growth inhibition: 551 nM
Compound 3: middle estimate off by 12-fold (1.07 log units), on the high side; measured number below the stated range.
By their numbers in this assay, from the lowest: compound 3; then compound 1; then compound 2.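

In this assay, plain phenyl on the carbonyl carbon, whose other neighbour is the amide-type nitrogen, gives an 8.6-fold lower number from compound 2 to compound 3 (0.94 log units; beyond the scatter), so the 4-chloro-3-(trifluoromethyl)phenyl group, with its additional heavy atoms, is not needed for growth inhibition in this set. Set against the (3,4-dichlorophenyl)amino group at the same place, phenyl also gives a 2.9-fold lower number from compound 1 to compound 3 (0.46 log units; beyond the scatter), which makes compound 3 the strongest inhibitor of growth among the three compounds and shows that the position can go well beyond the earlier pair in the direction of stronger inhibition. Nothing available accounts for either step, so the gain remains an observed difference without an explanation.

From the compounds shown here alone, the chlorine and the trifluoromethyl group of compound 2 change together in this comparison, so it remains open whether either one alone, as in 4-chlorophenyl or 3-(trifluoromethyl)phenyl, carries the loss seen against compound 3. Also open, going by these compounds, is how the position responds to an unsubstituted phenylamino group, which would separate the effect of the urea-type link in compound 1 from that of its two chlorines, or to a smaller group such as methyl or a saturated ring such as cyclohexyl.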